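The source may report more compounds than this note shows. Statements on the series, on what has been measured and on what is new or still open speak of the compounds shown alone.

Working notes on the series: compound 1 `CCCc1cc(-c2cn([C@H]3C[C@H](OC(C)=O)[C@@H](COC(C)=O)O3)c(=O)[nH]c2=O)on1` gives 3000 nM in an ADME assay on HeLa cells (Homo sapiens) for cytotoxicity (a higher number here means that more compound is tolerated, a lower number that less compound is tolerated), and compound 2 `CC(=O)OC[C@H]1O[C@@H](n2cc(-c3cc(-c4ccc(C(C)(C)C)cc4)no3)c(=O)[nH]c2=O)C[C@@H]1OC(C)=O` gives 3000 nM in the same read-out. Compound 3 `CC(=O)OC[C@H]1O[C@@H](n2cc(-c3cc(-c4ccc(C(C)C)cc4)no3)c(=O)[nH]c2=O)C[C@@H]1OC(C)=O` gives 3000 nM and so stands level with compounds 1 and 2 at the digits shown. Compound 4 `CCCCc1ccc(-c2cc(-c3cn([C@H]4C[C@H](OC(C)=O)[C@@H](COC(C)=O)O4)c(=O)[nH]c3=O)on2)cc1` has not yet been measured.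

The change to compound 4 is butyl in place of isopropyl on an aromatic carbon, para to a large group (butyl in place of isopropyl on an aromatic carbon). The closest measured evidence is no change at the digits printed from compound 2 to compound 3 (within the scatter) for hydrogen in place of methyl in the group that leaves here. Larger swaps also moved nothing: no change at the digits printed from compound 1 to compound 2 (within the scatter) and no change at the digits printed from compound 1 to compound 3 (within the scatter) for 4-(tert-butyl)phenyl and 4-isopropylphenyl in place of propyl.

None of these steps goes beyond the scatter, so no step beyond it, in either direction, is expected in this assay. The expected size is no change at the digits printed from compound 3 to compound 4 (within the scatter) on this basis. The estimate for compound 4 is 3000 nM (range 1500 nM to 6000 nM).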

Compound 4, half-maximal cytotoxic concentration: 3000 nM
Compound 4: middle estimate and measured number agree at the digits printed, within the range that was stated.
By their numbers in this assay, from the lowest: compounds 1, 2, 3 and 4 (each within the scatter of the next).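

Butyl is the first unbranched chain on this aromatic carbon, para to a large group, and in this assay it reads the same as the branched groups: no change at the digits printed from compound 3 to compound 4 (within the scatter) against isopropyl and no change at the digits printed from compound 2 to compound 4 (within the scatter) against tert-butyl. The 4-butylphenyl group also fits the earlier comparison with the propyl compound, with no change at the digits printed from compound 1 to compound 4 (within the scatter), so within these compounds neither the branching of this substituent nor the swap of propyl for a substituted phenyl gives a step beyond the scatter. No measurement available here explains this flat read-out.

On these data alone, whether an amine or a carboxylic acid on this aromatic carbon would leave the value within the scatter remains open. Also open, as far as these compounds go, is whether free hydroxyl groups in place of the two acetate esters on the shared core would do the same.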